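A few compounds are considered here, and "the series" means these few. Any claim that something is new, unique, unknown or untested is made for them only; others in the source may bear on it.

Three compounds have been examined in an assay on RPMI-8226 cells for antagonist activity at P2X purinoceptor 7 (Homo sapiens), read by calcium flux (a higher number here means a weaker inhibitor, a lower number a stronger inhibitor), and two of them reach only the edge of the test. Compound 1 `O=c1[nH]c2ccccc2n1CCCN1CCN(S(=O)(=O)c2ccc([N+](=O)[O-])cc2)CC1` gives > 10000 nM in this assay, a limit rather than a number. Compound 2 `O=c1[nH]c2ccccc2n1C/C=C/CN1CCN(C(c2ccccc2)c2ccccc2)CC1` likewise gives > 10000 nM in this assay, again a limit. Going by the values given here, compound 3 `Cc1cccc2c1ccn2CCCCN1CCN(C(c2ccccc2)c2ccccc2)CC1` is the one compound with a measured value, giving 5300 nM in this assay. On the numbers shown compound 3 therefore stands alone, whereas compound 1 and compound 2 sit at the limit described by the limit of > 10000 nM in this assay, at which 2 of the 3 values shown sit.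

Compound 4 `c1ccc(-c2nnnn2CCCCN2CCN(C(c3ccccc3)c3ccccc3)CC2)cc1` has not yet been measured in this assay. It differs from compound 3 in one place: a group of 11 heavy atoms (7 carbon, 4 nitrogen; one five-membered aromatic ring with 4 hetero atoms, one six-membered aromatic ring of carbon only) in place of a group of 10 heavy atoms (9 carbon, 1 nitrogen; one five-membered aromatic ring with 1 hetero atom, one six-membered aromatic ring of carbon only), on a saturated chain carbon, four bonds along the chain from an amine nitrogen in a ring. Among the compounds with values here, with no measured pair of this kind to lean on, the step from compound 3 to compound 4 is expected to stay within the usual scatter, with some chance that compound 4 again returns only a limit. Compound 4 is therefore estimated at 6000 nM in this assay, within a range of 2000 nM to 20000 nM, which amounts to an expected step of a 1.1-fold higher number from compound 3 to compound 4 (0.05 log units; within the scatter).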

Compound 4, half-maximal inhibitory concentration: 3200 nM
The estimate for compound 4 lay 1.9-fold (0.27 log units) above the measured number, and the stated range covers the measured number.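

Compound 3 and compound 4 are the only pair shown that differs in one place, so they give the first direct reading of this position, the saturated chain carbon four bonds along the chain from an amine nitrogen in a ring. In this assay, replacing the earlier two-ring group with 5-phenyl-1H-tetrazol-1-yl gives a 1.7-fold lower number from compound 3 to compound 4 (0.22 log units; within the scatter), so a group with four ring nitrogens instead of one still gives a measured value, and the step does not separate the two compounds. Nothing measured here gives a cause for this step.

From the compounds shown here alone, what a carboxylic acid or a simple amine would do at this position remains open. So does the effect of a longer chain than the one shared by compound 3 and compound 4.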